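Opening a flexible amide on the shared core

The source may report more compounds than this note shows. Statements on the series, on what has been measured and on what is new or still open speak of the compounds shown alone.

For the measured compounds named here, compound 2 `O=C(Cn1c(-c2ccc(Cl)cc2)nc2cccnc21)N1CCCC1` is tested in a functional assay on the whole organism with Mus musculus as the target (a lower number here means that less compound is needed, a higher number that more compound is needed for the effect), where compound 2 gives 17.9 mg/kg, the lowest of the two numbers known. Going by the values given here, the only other measured compound, compound 1 `COc1ccc(-c2nc3cccnc3n2CC(=O)N(C)C)cc1`, gives 39.5 mg/kg in this assay. Compound 3 `CN(C)CCN(C)C(=O)Cn1c(-c2ccc(Cl)cc2)nc2cccnc21` is not yet measured; it differs from compound 2 by (2-(dimethylamino)ethyl)(methyl)amino in place of pyrrolidin-1-yl on a carbonyl carbon. Among the compounds with values here, no measured pair shows what such a change does on this core, so the step is expected to be small, in either direction or none beyond the scatter. The step from compound 2 to compound 3 is therefore estimated at a 1.1-fold higher number from compound 2 to compound 3 (0.05 log units; within the scatter). For compound 3 the expected dose in this assay is 20 mg/kg, within a range of 8 mg/kg to 50 mg/kg.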

Compound 3, dose for half-maximal effect: 100 mg/kg
Beside the measured number, compound 3's estimate is 5.0-fold (0.70 log units) below it; measured number above the stated range.
By their numbers in this assay, from the lowest: compound 2; then compound 1; then compound 3.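

In this assay, putting (2-(dimethylamino)ethyl)(methyl)amino in place of pyrrolidin-1-yl on the carbonyl carbon gives a 5.6-fold higher number from compound 2 to compound 3 (0.75 log units; beyond the scatter), so the dose at this position does respond to the group on the amide. This is the only step shown between compounds that differ in one place, and it concerns this single pair. No evidence is available to account for it.

The compounds shown leave open whether the loss of the ring or the added dimethylamino end of the chain carries the step. A piperidine ring, a morpholine ring or a plain diethylamino group on the same carbonyl carbon would bear on that question.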